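The compounds below may be only part of what the source reports. "The series", "measured", "known", "first", "only" and "open" are said of these compounds alone.

Compound 1 `N#Cc1cccc(-n2nnc(-c3ccccn3)n2)c1` and compound 2 `N#Cc1cc(-n2nnc(-c3ccccn3)n2)cc([N+](=O)[O-])c1` share one core, and both were tested in a functional assay with metabotropic glutamate receptor 5 (Rattus norvegicus) as the target; on this read-out higher numbers stand for weaker inhibition and lower numbers for stronger inhibition. Compound 1 stands at 73 nM and compound 2 at 42 nM, the two lying within the scatter of each other. Among the measured compounds shown here, the only step known, a 1.7-fold lower number from compound 1 to compound 2 (0.24 log units; within the scatter), placed a nitro group on the ring. Compound 3 `N#Cc1cc(N)cc(-n2nnc(-c3ccccn3)n2)c1` differs from compound 1 by amino in place of hydrogen on an aromatic carbon. For the measured compounds named here, since the single comparable step stayed within the scatter, no shift beyond it is expected here. For compound 3 the estimate is 60 nM, between 25 nM and 150 nM, which would be a step of a 1.2-fold lower number from compound 1 to compound 3 (0.09 log units; within the scatter).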

Compound 3, half-maximal inhibitory concentration: 308 nM
The estimate for compound 3 lay 5.1-fold (0.71 log units) below the measured number; the whole stated range lies below it.
By their numbers in this assay, from the lowest: compounds 2 and 1 (each within the scatter of the next); then compound 3.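

This ring position is sensitive to what is placed on it: amino in place of hydrogen gives a 4.2-fold higher number from compound 1 to compound 3 (0.63 log units; beyond the scatter) and moves the number beyond the scatter, which the nitro step had not done. Amino in place of nitro gives a 7.3-fold higher number from compound 2 to compound 3 (0.87 log units; beyond the scatter) and shows that these two groups are not interchangeable here. Nothing available explains this change.

As far as these compounds go, it remains open how a methylamino, acetamido, hydroxyl or fluoro group would behave at this position. It is also unclear whether amino would give a similar step elsewhere on the ring.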